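The compounds below may be only part of what the source reports. "The series", "measured", "known", "first", "only" and "open" are said of these compounds alone.

Working notes on the series.

Among the measured compounds shown here, compound 3 `Cc1ccc(OCC(=O)N(Cc2cccs2)c2c(C)n[nH]c2C)cc1` stands lowest of the three numbers measured so far: in an assay on HEK293 cells for agonist activity at transient receptor potential cation channel subfamily M member 8 (Homo sapiens), read by fluorescence and calcium flux, with a stated time of 15 min (on this read-out lower numbers stand for an effect already at smaller amounts and higher numbers for an effect only at larger amounts of compound), compound 3 gives 0.3 nM. Its nearest neighbour is compound 1 `CON(Cc1cccs1)C(=O)COc1ccc(C)cc1`, which in this assay gives 10 nM; the furthest is compound 2 `Cc1ccc(OCC(=O)N(Cc2cccs2)c2nccs2)cc1`, which in this assay gives 2240 nM.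

The step to compound 4 `Cc1ccc(OCC(=O)N(Cc2cccs2)c2cnn(C)c2)cc1` is 1-methyl-1H-pyrazol-4-yl in place of 3,5-dimethyl-1H-pyrazol-4-yl on an amide-type nitrogen. The steps already seen at this position are all large: a 33-fold lower number from compound 1 to compound 3 (1.52 log units; beyond the scatter), a 220-fold higher number from compound 1 to compound 2 (2.35 log units; beyond the scatter) and a 7500-fold lower number from compound 2 to compound 3 (3.87 log units; beyond the scatter). The same amide-type nitrogen therefore carries the whole spread of the series, and the 3,5-dimethyl-1H-pyrazol-4-yl group sits at the favourable end. For the measured compounds named here, compound 4 keeps a five-membered aromatic ring with 2 hetero atoms at that position but loses the hydrogen-bond donor and both ring methyls; no measured pair separates these two parts of the change, and the only other donor-free heteroaryl at this position, in compound 2, sits far above compound 3.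

Compound 4 is therefore expected to give a higher number than compound 3, a step of a 50-fold higher number from compound 3 to compound 4 (1.70 log units; beyond the scatter), short of the full gap seen with compound 2. The estimate for compound 4 in this assay is 15 nM, with a range from 1 nM to 300 nM.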

Compound 4, half-maximal effective concentration: 63000 nM
Compound 4: middle estimate off by 4200-fold (3.62 log units), on the low side; measured number outside the range, above it.
By their numbers in this assay, from the lowest: compound 3; then compound 1; then compound 2; then compound 4.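

The group on the amide-type nitrogen matters far more than the ring type suggests: the 3,5-dimethyl-1H-pyrazol-4-yl and 1-methyl-1H-pyrazol-4-yl groups are both five-membered aromatic rings with 2 hetero atoms, yet they stand at opposite ends of the series in this assay, with a 210000-fold higher number from compound 3 to compound 4 (5.32 log units; beyond the scatter). The 1-methyl-1H-pyrazol-4-yl group also gives a higher number than the other two groups at this position, with a 28-fold higher number from compound 2 to compound 4 (1.45 log units; beyond the scatter) and a 6300-fold higher number from compound 1 to compound 4 (3.80 log units; beyond the scatter), so it now marks the unfavourable end of the range in place of the 1,3-thiazol-2-yl group. Nothing on hand offers an explanation for the size of these steps.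

The step from compound 3 to compound 4 combines loss of the hydrogen-bond donor with loss of both ring methyls, and the compounds shown do not separate these parts; an unsubstituted 1H-pyrazol-4-yl group and a 1,3,5-trimethyl-1H-pyrazol-4-yl group would each bear on that question. From the compounds shown here alone, whether a 3,5-dimethyl-1,2-oxazol-4-yl group at the same place would keep a low number also remains open.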